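Aryl exchange at the carbonyl: compound 2 to compound 3

The source may report more compounds than this note shows. Statements on the series, on what has been measured and on what is new or still open speak of the compounds shown alone.

Two compounds of the series have numbers in a functional assay on WI-38 VA13 cells (Homo sapiens) for cytotoxicity; a higher number here means that more compound is needed for the effect, a lower number that less compound is needed. Compound 1 `Cn1ncc([N+](=O)[O-])c1C(=O)Nc1ccc2nc(NC(=O)C3CCCCC3)sc2c1` gives 0.026 ug/mL. Compound 2 `Cc1ccc(C(=O)Nc2ccc3nc(NC(=O)C4CCCCC4)sc3c2)cc1` gives 5.1 ug/mL, the highest of the two numbers; its nearest neighbour is compound 1, and the step of a 200-fold higher number from compound 1 to compound 2 (2.29 log units; beyond the scatter) put 4-methylphenyl in place of 1-methyl-4-nitro-1H-pyrazol-5-yl on the carbonyl carbon.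

Compound 3 `O=C(Nc1ccc2nc(NC(=O)C3CCCCC3)sc2c1)c1ccc(Cl)cc1Cl` is not yet measured. It differs from compound 2 by 2,4-dichlorophenyl in place of 4-methylphenyl on a carbonyl carbon; the 2,4-dichlorophenyl group sits on the carbonyl carbon whose other neighbour is an amide-type nitrogen, and the shared core is untouched.

Going by the values given here, no measured step bears on an exchange of one carbon-only six-membered aromatic ring for another at this carbonyl. Among the compounds with values here, the only step on record, a 200-fold higher number from compound 1 to compound 2 (2.29 log units; beyond the scatter), concerns a different exchange and sets no expectation here. With compound 2 at 5.1 ug/mL as the anchor, compound 3 is expected to give 5 ug/mL, within 1.5 ug/mL to 16 ug/mL. The step of a 1.0-fold lower number from compound 2 to compound 3 (0.01 log units; within the scatter) is expected to stay near the scatter of this assay.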

Compound 3, half-maximal effective concentration: > 4 ug/mL
Compound 3 ended at the assay's limit (the forecaster's own chance of this, stated with the estimate: 5%); the middle value does not contradict the limit.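

In this assay compound 3 stands at a limit of the assay, > 4 ug/mL, and this value is a limit, not a number. Against 1-methyl-4-nitro-1H-pyrazol-5-yl on the carbonyl carbon, 2,4-dichlorophenyl gives an at least 150-fold higher number from compound 1 to compound 3 (2.18 log units; beyond the scatter), so the large step seen earlier with 4-methylphenyl is no longer tied to that one group: two different carbon-only six-membered aromatic rings now stand on the same side of compound 1. The exchange of one such ring for the other cannot be read because the new value ends at the limit: the limit of > 4 ug/mL in this assay, at which 1 of the 3 values shown sits.

Still open, from the compounds shown here alone, is how 2,4-dichlorophenyl and 4-methylphenyl rank against each other at this carbonyl carbon, since a limit gives no size for that exchange. Also open, going by these compounds, is whether the low number of compound 1, 0.026 ug/mL, would hold with an amine or a carboxylic acid in place of the nitro group on the 1-methyl-4-nitro-1H-pyrazol-5-yl ring, which would show whether that group or the ring itself goes with the low number.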